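From methoxy to carbamoyl on the cyclohexyl group

The compounds below may be only part of what the source reports. "The series", "measured", "known", "first", "only" and "open" are said of these compounds alone.

Measured in an ADME assay on S9 fraction from liver (Homo sapiens) for metabolic stability, with a stated time of 1 h; a higher number here means that more of the compound is left, a lower number that less of the compound is left:
- compound 1 `N#Cc1cnc(NCc2cnccc2C(F)(F)F)cc1N[C@H]1CC[C@H](O)CC1` gives 30%
- compound 2 `N#Cc1cnc(NCc2cnccc2C(F)(F)F)cc1NC[C@H]1CC[C@@H](O)CC1` gives 41%
- compound 3 `CO[C@H]1CC[C@@H](CNc2cc(NCc3cnccc3C(F)(F)F)ncc2C#N)CC1` gives 4%

Compound 3 stands lowest of the three, and its gaps to compound 1 and compound 2 both lie beyond the scatter. The next structure is compound 4 `N#Cc1cnc(NCc2cnccc2C(F)(F)F)cc1N[C@H]1CC[C@@H](C(N)=O)CC1`, and the change from compound 3 is 4-carbamoylcyclohexyl in place of (4-methoxycyclohexyl)methyl on a nitrogen on an aromatic ring. The same difference, cut one bond further out, reads ((4-methoxycyclohexyl)methyl)amino to (4-carbamoylcyclohexyl)amino. Two measured comparisons bear on this. Methyl in place of hydrogen on the oxygen gave the large step of a number 37 percentage points lower from compound 2 to compound 3 (beyond the scatter) in this assay, and compound 4 no longer carries that methoxy group. The attachment of the ring in compound 4 matches that of compound 1, and the change of attachment with the hydroxy group kept gave only the modest step of a number 11 percentage points higher from compound 1 to compound 2 (beyond the scatter). Among the measured compounds shown here, the carbamoyl group itself appears in no measured compound, so the expectation rests on compound 1 at 30% and compound 2 at 41% as the nearest references. A large upward move is therefore expected, and the estimated change is a number 31 percentage points higher from compound 3 to compound 4 (beyond the scatter). For compound 4 the expected value is 35%, with an estimated range from 12% to 65%.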

Compound 4, percent of the compound remaining: 90%
Estimate against measurement, compound 4: 55 percentage points below; measured number above the stated range.
By their numbers in this assay, from the lowest: compound 3; then compound 1; then compound 2; then compound 4.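

In this assay, the carbamoyl group on the cyclohexyl ring gives the highest number in the series, with a result of a number 86 percentage points higher from compound 3 to compound 4 (beyond the scatter), a reach that neither the hydroxy nor the methoxy compounds had suggested for this position. The gain does not depend on removing the methoxy group alone, since the hydroxy compounds also fall well short: the comparison with the (4-hydroxycyclohexyl)methyl compound gives a number 49 percentage points higher from compound 2 to compound 4 (beyond the scatter), and the comparison with the 4-hydroxycyclohexyl compound, which has the same ring attachment, gives a number 60 percentage points higher from compound 1 to compound 4 (beyond the scatter), far larger than the earlier change of attachment (a number 11 percentage points higher from compound 1 to compound 2 (beyond the scatter)). What lies behind the carbamoyl result remains unexplained, as nothing available here bears on it.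

On these data alone, it remains open whether the carbamoyl group would hold this number on the (cyclohexyl)methyl attachment, which would separate the contribution of the group from that of the attachment. As far as these compounds go, it is also open whether the result is specific to the primary amide or extends to a carboxylic acid or an N-methyl amide in its place.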